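Adding a chloro group to compound 3

This account rests on a few compounds, and the source may have more. Where it says the series, first, only, none or still open, it means among the compounds named here.

- Compound 1 `COc1ccc(Cl)cc1C(=O)Nc1ccc(Br)cc1O` (7980 nM)
- Compound 2 `COc1cc(Cl)ccc1C(=S)Nc1ccc(Cl)cc1O` (5110 nM)
- Compound 3 `COc1cc(Cl)ccc1C(=S)Nc1cc(Cl)ccc1O` (8490 nM)

All three values come from a functional assay on HepG2 cells (Homo sapiens) for cytotoxicity, with a stated time of 24 h (a higher number here means a weaker inhibitor, a lower number a stronger inhibitor), and they sit close together. Compound 3 (8490 nM) lies within the usual scatter of both compound 1 and compound 2, so on these numbers it cannot be set apart from either.

Compound 4 `COc1cc(Cl)ccc1C(=S)Nc1cc(Cl)c(Cl)cc1O` has not yet been measured. It comes from compound 3 by a single change (chloro in place of hydrogen on an aromatic carbon), chloro in place of hydrogen on an aromatic carbon, ortho to a chloro group, meta to a hydroxy group and para to a large group.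

Within the data shown here, no two measured compounds differ in just one place, so nothing here shows directly what such a change does in this assay for these compounds. With so little to go on, only a small move toward a lower number is expected, one that may not rise beyond the scatter. That expectation leans on compound 1 (7980 nM) and compound 2 (5110 nM), which stay close to compound 3. The estimated move is a 1.7-fold lower number from compound 3 to compound 4 (0.23 log units; within the scatter) and it remains uncertain. For compound 4 the expected value is 5000 nM (estimated range 2000 nM to 12000 nM).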

Compound 4, half-maximal inhibitory concentration: 3160 nM
Beside the measured number, compound 4's estimate is 1.6-fold (0.20 log units) above it; the range from low to high includes it.
By their numbers in this assay, from the lowest: compounds 4, 2, 1 and 3 (each within the scatter of the next, the first and the last beyond it).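

In this assay, among these compounds, a chloro group placed ortho to a chloro group, meta to a hydroxy group and para to a large group gives the first direct reading of this change: a 2.7-fold lower number from compound 3 to compound 4 (0.43 log units; beyond the scatter), a modest step that clears the usual scatter. Compound 4 can also be reached from compound 2 by putting chloro in place of hydrogen on an aromatic carbon, but that step, a 1.6-fold lower number from compound 2 to compound 4 (0.21 log units; within the scatter), stays within the scatter, so the same kind of change shows a clear effect from only one of the two starting compounds. No measurement shown here accounts for the size of either step.

The compounds shown leave open whether a fluoro group, a methyl group or an amine at this same position would move the number as chloro does. They also leave open whether adding chloro here would have a similar effect on the core of compound 1, which carries a carbonyl where compound 3 carries a thiocarbonyl.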